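The compounds below may be only part of what the source reports. "The series", "measured", "known", "first", "only" and "open" are said of these compounds alone.

Compound 1 `Cc1nc(C)c([C@H](OC(C)(C)C)C(=O)O)c(N2CCC(C)(C)CC2)c1-c1ccc(-c2ccccc2)cc1` in a toxicity assay on MT2 cells (Homo sapiens) for cytotoxicity, read by XTT assay, with a stated time of 4 days (on this read-out higher numbers stand for lower toxicity in this test and lower numbers for higher toxicity in this test), reaches only the assay limit, >= 20000 nM.
Compound 2 `Cc1nc(C)c([C@H](OC(C)(C)C)C(=O)O)c(N2CCC(C)(C)CC2)c1-c1ccc(Oc2ccccc2)cc1` in this assay likewise reaches only a limit, >= 20000 nM.
Compound 3 `Cc1ccc(CCOc2ccc(-c3c(C)nc(C)c([C@H](OC(C)(C)C)C(=O)O)c3N3CCC(C)(C)CC3)cc2)cc1` in this assay also reaches only a limit, >= 33500 nM.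

Compound 1 therefore stands at a limit rather than a number, (the limit of >= 20000 nM in this assay, at which 2 of the 3 values shown sit), with compound 3 sitting at the other limit, (the limit of >= 33500 nM in this assay, at which 1 of the 3 values shown sits). Compound 4 `COc1ccc(CCOc2ccc(-c3c(C)nc(C)c([C@H](OC(C)(C)C)C(=O)O)c3N3CCC(C)(C)CC3)cc2)cc1` is the unmeasured compound. The measured steps that bear on it are a step that the two limits leave unreadable from compound 1 to compound 2 and a step that the two limits leave unreadable from compound 1 to compound 3, and neither can be read because both ends are limits. The change itself is 2-(4-methoxyphenyl)ethoxy in place of phenyl on an aromatic carbon. Since every related compound sits at a limit, compound 4 is expected to show no step beyond the scatter, a step that the limit leaves unreadable from compound 1 to compound 4. Compound 4 is estimated at 30000 nM, within 15000 nM to 80000 nM, most likely again reported as a limit.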

Compound 4, half-maximal cytotoxic concentration: >= 33500 nM
Compound 4: no number, only a limit; the forecaster's own chance of this, stated with the estimate: 85%; at least 1.1-fold (0.04 log units) between middle value and limit.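

In this assay compound 4 reaches only a limit, >= 33500 nM. Among these compounds, no step between compound 4 and compound 1, compound 2 or compound 3 can be read. The compounds shown leave open whether any of these changes shifts the half-maximal cytotoxic concentration at all.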